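Swapping Methoxy for Fluoro on the Aromatic Ring

The source may hold more compounds than are shown below. What is called first, only, known or untested is meant among the compounds shown, and "the series" means these compounds.

Of the compounds shown here, three have been measured in an ADME assay on RD cells (Homo sapiens) for cytotoxicity, read by MTT assay, with a stated time of 3 days; a higher number here means that more compound is tolerated, a lower number that less compound is tolerated. Compound 1 `CC[C@@H](CCn1cncn1)c1ccc(F)cc1` gives 91.6 ug/mL. Compound 2 `CCC[C@@H](CCn1cncn1)c1ccc(F)cc1` gives 56.9 ug/mL, and a 1.6-fold lower number from compound 1 to compound 2 (0.21 log units; within the scatter) stays within the scatter. Compound 3 `CCCC[C@@H](CCn1cncn1)c1ccc(OC)cc1` gives 39.4 ug/mL, which sits within the scatter of compound 2 but beyond it from compound 1. Compound 4 `CCCC[C@@H](CCn1cncn1)c1ccc(F)cc1` differs from compound 3 by fluoro in place of methoxy on an aromatic carbon. For the measured compounds named here, no measured step exchanges these two groups. Going by the values given here, the only known step, a 1.6-fold lower number from compound 1 to compound 2 (0.21 log units; within the scatter), concerns the chain and was within the scatter. Compounds 1 and 2 do carry fluoro, yet they differ from compound 4 in the chain as well. A step no larger than the scatter is therefore expected, namely a 1.1-fold higher number from compound 3 to compound 4 (0.06 log units; within the scatter). Compound 4 is estimated at 45 ug/mL, within 25 ug/mL to 80 ug/mL.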

Compound 4, half-maximal cytotoxic concentration: 34.1 ug/mL
The estimate for compound 4 lay 1.3-fold (0.12 log units) above the measured number; measured number inside the range.
By their numbers in this assay, from the lowest: compounds 4, 3, 2 and 1 (each within the scatter of the next, the first and the last beyond it).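

For the compounds shown here, this is the first direct exchange on this aromatic carbon, and in this assay fluoro in place of methoxy gives a 1.2-fold lower number from compound 3 to compound 4 (0.06 log units; within the scatter) and so leaves the two groups indistinguishable here. Going by these compounds alone, with fluoro held fixed, methyl in place of hydrogen on the chain gives a 1.7-fold lower number from compound 2 to compound 4 (0.22 log units; within the scatter) and ethyl in place of hydrogen gives a 2.7-fold lower number from compound 1 to compound 4 (0.43 log units; beyond the scatter) and only this last step lies beyond the scatter. No evidence accompanies these numbers to account for them.

From the compounds shown here alone, whether a hydroxyl, an amine or a chlorine on this aromatic carbon would fall within the same scatter remains open, as does the effect of a longer chain.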